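A few compounds are considered here, and "the series" means these few. Any claim that something is new, unique, unknown or untested is made for them only; others in the source may bear on it.

Measured compounds in a functional assay on A549 cells (Homo sapiens) for cytotoxicity, read by MTT assay, with a stated time of 24 h; on this read-out higher numbers stand for weaker inhibition and lower numbers for stronger inhibition:
- compound 1 `CC[C@H](C)[C@@H](NC(=O)Cn1cc(C2=C(c3c[nH]c4ccccc34)C(=O)N(C)C2=O)c2ccccc21)C(=O)OC`: > 100000 nM, a limit of the assay the limit of > 100000 nM in this assay, at which 1 of the 3 values shown sits.
- compound 2 `COC(=O)[C@@H](C)NC(=O)Cn1cc(C2=C(c3c[nH]c4ccccc34)C(=O)N(C)C2=O)c2ccccc21`: 30500 nM
- compound 3 `COC(=O)[C@@H](CO)NC(=O)Cn1cc(C2=C(c3c[nH]c4ccccc34)C(=O)N(C)C2=O)c2ccccc21`: 37900 nM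

Among the two actual numbers, compound 3 gives the higher one, though its nearest neighbour compound 2 lies within the scatter (a 1.2-fold higher number from compound 2 to compound 3 (0.09 log units; within the scatter)); the third value is the limit of compound 1. The next compound in the series is compound 4 `COC(=O)CC[C@@H](NC(=O)Cn1cc(C2=C(c3c[nH]c4ccccc34)C(=O)N(C)C2=O)c2ccccc21)C(=O)OC`, which differs from compound 3 by (methoxycarbonyl)methyl in place of hydroxy on a saturated chain carbon, two bonds along the chain from an amide-type nitrogen and a carbonyl carbon.

Among the compounds with values here, two measured steps bear on the side chain at this position. From the compounds shown here alone, replacing sec-butyl with methyl gave an at least 3.2-fold lower number from compound 1 to compound 2 (0.51 log units; beyond the scatter), and replacing it with hydroxymethyl gave an at least 2.6-fold lower number from compound 1 to compound 3 (0.42 log units; beyond the scatter); both start from a limit, so their true size is unknown, only their direction. Within the data shown here, compound 4 moves in the opposite direction, from a small group toward a longer side chain like the one compound 1 carries. The step from hydrogen to hydroxy, a 1.2-fold higher number from compound 2 to compound 3 (0.09 log units; within the scatter), was without effect. The expectation is therefore a higher number for compound 4 in this assay, of modest size, a 1.7-fold higher number from compound 3 to compound 4 (0.23 log units; within the scatter), with a real chance that the assay reports only a limit. Compound 4 is estimated at 65000 nM, range 25000 nM to 170000 nM.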

Compound 4, half-maximal inhibitory concentration: 73700 nM
Beside the measured number, compound 4's estimate is 1.1-fold (0.05 log units) below it; low and high end bracket the measured number.
By their numbers in this assay, from the lowest: compounds 2, 3 and 4 (each within the scatter of the next, the first and the last beyond it). At a limit, above all of these: compound 1.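

In this assay, this position now gives its first step between two actual numbers that lies beyond the scatter: a 2.4-fold higher number from compound 2 to compound 4 (0.38 log units; beyond the scatter), on going from the methyl group to the 2-(methoxycarbonyl)ethyl chain. Against the hydroxymethyl group the same chain gives a 1.9-fold higher number from compound 3 to compound 4 (0.29 log units; within the scatter), so the two side chains cannot be ordered on this read-out, and the series so far separates only its two end members with actual numbers, compound 2 and compound 4. Compound 1 remains a limit, and an at least 1.3-fold lower number from compound 1 to compound 4 (0.13 log units; that floor lies within the scatter) therefore gives no order between the sec-butyl and 2-(methoxycarbonyl)ethyl chains.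

From the compounds shown here alone, it remains open whether the step from methyl follows the length of the chain or the ester at its end: the free carboxylic acid of the same chain and a plain unbranched butyl chain would separate the two. Also open, going by these compounds, is whether any side chain at this position brings the number well below that of compound 2, for instance a chain ending in an amine or a benzyl group.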